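This account rests on a few compounds, and the source may have more. Where it says the series, first, only, none or still open, it means among the compounds named here.

Measured in a functional assay on MCF7 cells (Homo sapiens) for inhibition, read by sulforhodamine B assay; a higher number here means a weaker inhibitor, a lower number a stronger inhibitor:
- compound 1 `O=C1C(Nc2ccc(Br)cc2)=CC(=O)c2c1nc1n2[C@H]2OC[C@@H](O)[C@H]2OC1`: 4330 nM
- compound 2 `O=C1C=C(Nc2ccccc2F)C(=O)c2c1nc1n2[C@H]2OC[C@@H](O)[C@H]2OC1`: 3640 nM
- compound 3 `O=C1C=C(NC2CCCCC2)C(=O)c2c1nc1n2[C@H]2OC[C@@H](O)[C@H]2OC1`: > 8000 nM

For the measured compounds named here, compound 1 at 4330 nM lies within the scatter of compound 2 at 3640 nM, and these are the only two true numbers so far. Compound 3 gives no number, only a limit of the assay, (the limit of > 8000 nM in this assay, at which 1 of the 3 values shown sits).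

The next compound, compound 4 `O=C1C(N2CCCC2)=CC(=O)c2c1nc1n2[C@H]2OC[C@@H](O)[C@H]2OC1`, carries pyrrolidin-1-yl in place of (4-bromophenyl)amino on a double-bonded ring carbon. Going by the values given here, only one measured step bears on this change: an at least 2.1-fold higher number from compound 2 to compound 3 (0.34 log units; beyond the scatter). That step also trades an aromatic ring for a non-aromatic one, as the change to compound 4 does. Among the compounds with values here, no measured compound shows what losing the hydrogen-bond donor does, so this guide is indirect.

The expected step is a 2.1-fold higher number from compound 1 to compound 4 (0.32 log units; beyond the scatter), toward a weaker inhibitor. For compound 4 the estimated value is 9000 nM, with an expected range from 4000 nM to 20000 nM.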

Compound 4, half-maximal inhibitory concentration: > 16000 nM
Compound 4 gave a limit, no number; the forecaster's own chance of this, stated with the estimate: 50%; at least 1.7-fold (0.24 log units) between middle value and limit.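

Compound 4 gives no number, only a limit of the assay: the limit of > 16000 nM in this assay, at which 1 of the 4 values shown sits.

At this place, a double-bonded ring carbon, pyrrolidin-1-yl in place of (4-bromophenyl)amino gives an at least 3.6-fold higher number from compound 1 to compound 4 (0.56 log units; beyond the scatter), and the true gap may be larger. The earlier step swapped one ring on an amine nitrogen for another and kept the hydrogen-bond donor, whereas this change removes both the aromatic ring and the donor, and the result still points toward a weaker inhibitor.

Because both features leave together, the compounds shown cannot say which one matters, or whether the smaller group plays a part. A methyl(phenyl)amino group, which keeps the aromatic ring without the donor, and a cyclopentylamino group, which keeps the donor without the aromatic ring, would pull these apart at this position.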